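This account rests on a few compounds, and the source may have more. Where it says the series, first, only, none or still open, it means among the compounds named here.

Compound 2 `COc1ccc(S(=O)(=O)Nc2cc(Br)cc(Br)c2Br)cc1N1CCNCC1` gives 2.51 nM in an assay on isolated protein for binding affinity to 5-hydroxytryptamine receptor 6 (Homo sapiens) (on this read-out lower numbers stand for stronger inhibition and higher numbers for weaker inhibition), the highest of the two numbers measured; its nearest neighbour is compound 1 `COc1ccc(S(=O)(=O)Nc2cc(Br)cc(Br)c2)cc1N1CCNCC1`, which gives 0.501 nM. Among the measured compounds shown here, the one measured step, a 5.0-fold higher number from compound 1 to compound 2 (0.70 log units; beyond the scatter), is a bromo in place of hydrogen on an aromatic carbon and lies beyond the scatter. Compound 3 `COc1ccc(S(=O)(=O)Nc2cc(Br)cc(F)c2Cl)cc1N1CCNCC1` is not yet measured. It differs from compound 2 by 5-bromo-2-chloro-3-fluorophenyl in place of 2,3,5-tribromophenyl on a sulfonamide nitrogen. For the measured compounds named here, that change swaps halogens on the ring attached to the sulfonamide nitrogen rather than adding or removing one, so no measured step matches it directly; the step from compound 1 to compound 2 only shows that the bromo on that ring costs affinity. Compound 3 is therefore expected to land between its two neighbours, a step of a 1.6-fold lower number from compound 2 to compound 3 (0.20 log units; within the scatter) in this assay, giving an estimated 1.6 nM with a likely range from 0.5 nM to 5 nM.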

Compound 3, inhibition constant: 3.16 nM
Compound 3: the middle estimate sits 2.0-fold (0.30 log units) below what was measured, within the range that was stated.
By their numbers in this assay, from the lowest: compound 1; then compounds 2 and 3 (each within the scatter of the next).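

In this assay, 5-bromo-2-chloro-3-fluorophenyl in place of 2,3,5-tribromophenyl on the sulfonamide nitrogen gives a 1.3-fold higher number from compound 2 to compound 3 (0.10 log units; within the scatter), so this read-out does not tell these two halogen patterns apart. The higher number first seen with 2,3,5-tribromophenyl is therefore not confined to that group: measured against the 3,5-dibromophenyl of compound 1, the new group gives a 6.3-fold higher number from compound 1 to compound 3 (0.80 log units; beyond the scatter). Across these three compounds, both groups that differ from 3,5-dibromophenyl sit beyond the scatter from compound 1, and no compound shown goes against this.

On these data alone, it remains open whether a ring carrying a methyl group, a nitrile or a trifluoromethyl group in place of these halogens on the sulfonamide nitrogen would match compound 1 or compound 3. No evidence is available on why these numbers fall as they do.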